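The source may report more compounds than this note shows. Statements on the series, on what has been measured and on what is new or still open speak of the compounds shown alone.

In a functional assay on HeLa cells (Homo sapiens) for antiproliferative activity, with a stated time of 48 h (a lower number here means a stronger inhibitor, a higher number a weaker inhibitor), compound 1 `C=C(Br)C(=O)Nc1ccc(C(=O)/C=C/c2ccc(OC)cc2)cc1` gives 310 nM, compound 2 `C=C(Br)C(=O)Nc1ccc(C(=O)/C=C/c2cccc(OC)c2)cc1` gives 500 nM and compound 3 `C=C(Br)C(=O)Nc1ccc(C(=O)/C=C/c2ccccc2OC)cc1` gives 1300 nM. These three differ only in where a single methoxy group sits on the aromatic ring. Compound 3 has the highest number of the three, and both of its gaps are modest: a 4.2-fold higher number from compound 1 to compound 3 (0.62 log units; beyond the scatter), and a 2.6-fold higher number from compound 2 to compound 3 (0.41 log units; beyond the scatter). The remaining pair stays within the scatter, with a 1.6-fold higher number from compound 1 to compound 2 (0.21 log units; within the scatter).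

Compound 4 `C=C(Br)C(=O)Nc1ccc(C(=O)/C=C/c2cccc(OC)c2OC)cc1` is compound 3 with one addition, methoxy in place of hydrogen on an aromatic carbon, ortho to a methoxy group and meta to a large group. Among the measured compounds shown here, no measured step adds a group, so only these moves of the methoxy group offer guidance. Compound 4 carries methoxy groups at the places they occupy in both compound 2 and compound 3, so part of a 2.6-fold higher number from compound 2 to compound 3 (0.41 log units; beyond the scatter) may be recovered. The expected change is small, a 1.5-fold lower number from compound 3 to compound 4 (0.18 log units; within the scatter), toward a lower number. For compound 4 the estimate is 850 nM, with an expected range of 330 nM to 2200 nM.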

Compound 4, half-maximal inhibitory concentration: 380 nM
Compound 4: the middle estimate sits 2.2-fold (0.35 log units) above what was measured; measured number inside the range.
By their numbers in this assay, from the lowest: compounds 1, 4 and 2 (each within the scatter of the next); then compound 3.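

In this assay, adding a methoxy group ortho to the methoxy group of compound 3, and meta to a large group, gives a 3.4-fold lower number from compound 3 to compound 4 (0.53 log units; beyond the scatter). Among the compounds shown here, this is the first added group, and it shows that this position accepts a methoxy group and that the addition can lower the number. Read from the other side, the same addition gives a 1.3-fold lower number from compound 2 to compound 4 (0.12 log units; within the scatter), so compound 2 and compound 4 cannot be told apart, and nothing measured here explains the result.

As far as these compounds go, it remains open whether a smaller or larger group at this position, such as a hydroxyl, a fluorine or an ethoxy group, would give the same result as methoxy. From the compounds shown here alone, it is also open whether adding a methoxy group to compound 1 would lower its number further.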